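Chloro for Fluoro on the Dibromo Core

This account rests on a few compounds, and the source may have more. Where it says the series, first, only, none or still open, it means among the compounds named here.

Compound 1 `O=[N+]([O-])c1cc(C(F)(F)F)cc([N+](=O)[O-])c1Oc1ccc(Cl)cc1/C=N\OCc1ccccc1F` and compound 2 `O=[N+]([O-])c1cc(C(F)(F)F)cc([N+](=O)[O-])c1Oc1ccc(Cl)cc1/C=N\OCc1ccccc1Cl` share one core and differ in a single place; compound 3 `O=[N+]([O-])c1cc(C(F)(F)F)cc([N+](=O)[O-])c1Oc1c(Br)cc(Br)cc1/C=N\OCc1ccccc1F` and compound 4 `O=[N+]([O-])c1cc(C(F)(F)F)cc([N+](=O)[O-])c1Oc1c(Br)cc(Br)cc1/C=N\OCc1ccccc1Cl` form a second such pair on another core. How the core of compound 3 differs from the core of compound 1 is not broken down here. In a functional assay on HepG2 cells (Homo sapiens) for antiproliferative activity, read by MTT assay, with a stated time of 48 h (on this read-out higher numbers stand for weaker inhibition and lower numbers for stronger inhibition), compound 1 gives 1020 nM. In the same assay compound 2 gives 1510 nM, and compound 3 gives 1100 nM.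

The change from compound 1 to compound 2, chloro in place of fluoro on an aromatic carbon, produced a 1.5-fold higher number from compound 1 to compound 2 (0.17 log units; within the scatter). Compound 4 carries the same change chloro in place of fluoro on an aromatic carbon on the core of compound 3, at a place described in identical words. Because a 1.5-fold higher number from compound 1 to compound 2 (0.17 log units; within the scatter) stayed within the scatter, compound 4 is expected to show a 1.5-fold higher number from compound 3 to compound 4 (0.18 log units; within the scatter), a step of about the same size as the earlier one. On that basis compound 4 is estimated at 1650 nM in this assay, with an expected range from 900 nM to 3000 nM.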

Compound 4, half-maximal inhibitory concentration: 2450 nM
Compound 4: the middle estimate sits 1.5-fold (0.17 log units) below what was measured; the range from low to high includes it.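

The second pair gives a 2.2-fold higher number from compound 3 to compound 4 (0.35 log units; beyond the scatter) in this assay, a modest step that clears the scatter, whereas the first pair's step did not. Even so, the two steps cannot be told apart, so the size of the change carried over from one core to the other as far as these pairs can show: the same change on two cores in this assay, a 1.5-fold higher number (0.17 log units; within the scatter) from compound 1 to compound 2 and a 2.2-fold higher number (0.35 log units; beyond the scatter) from compound 3 to compound 4, 1.5-fold (0.18 log units) apart, within the scatter of two such steps. For the compounds shown here, this supports the same step size on these two cores only; it does not show that the change would behave alike on a further core, nor does it fix the size of the step, since only two pairs bear on it and just one of the steps lies beyond the scatter.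

The compounds shown have only fluoro or chloro at this place, so they leave open how a bromine, a methyl group or a methoxy group would read there in this assay. They also leave open whether an amine or a carboxylic acid elsewhere on the benzyl ring would alter the step.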